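The compounds below may be only part of what the source reports. "The series", "measured", "known", "first", "only" and "open" are said of these compounds alone.

Measured in a functional assay on HT-29 cells (Homo sapiens) for antiproliferative activity, read by MTT assay, with a stated time of 48 h; on this read-out lower numbers stand for stronger inhibition and higher numbers for weaker inhibition:
Compound 1 `Cc1ccccc1/C=C1\CN(C(=S)NC(=O)c2ccccc2)C/C(=C\c2ccccc2C)C1=O`: < 10000 nM (a limit, not a number)
Compound 2 `Cc1ccc(/C=C2\CN(C(=S)NC(=O)c3ccccc3)C/C(=C\c3ccc(C)cc3)C2=O)cc1`: < 10000 nM (a limit, not a number)

Compound 2 stands only as a limit, and no number is available for it. The whole record so far is the limit of < 10000 nM in this assay, at which 2 of the 2 values shown sit. Compound 3 `CCCCNC(=S)N1C/C(=C\c2ccc(C)cc2)C(=O)/C(=C/c2ccc(C)cc2)C1` has butyl in place of benzoyl on an amide-type nitrogen whose other neighbour is the thiocarbonyl carbon (butyl in place of benzoyl on an amide-type nitrogen). For the measured compounds named here, no measured pair covers this change, so its size cannot be read from the data. In this assay no step beyond the scatter is expected, and no direction is favoured. The only anchor for this expectation is compound 2 with its limit of < 10000 nM. The expected step is a step that the limit leaves unreadable from compound 2 to compound 3. The estimated value for compound 3 is 5000 nM, with an expected range of 1500 nM to 15000 nM.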

Compound 3, half-maximal inhibitory concentration: < 10000 nM
Compound 3: a limit, no number (the forecaster's own chance of this, stated with the estimate: 45%); the middle value is on the limit's open side.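

No step can be read between compound 2 and compound 3 in this assay, as each stands only as a limit and not a number: the limit of < 10000 nM in this assay, at which 3 of the 3 values shown sit.

The compounds shown leave open what size of change, if any, butyl in place of benzoyl on an amide-type nitrogen brings.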